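The source may report more compounds than this note shows. Statements on the series, on what has been measured and on what is new or still open speak of the compounds shown alone.

In a functional assay on SMMC-7721 cells (Homo sapiens) for cytotoxicity, read by MTT assay, with a stated time of 24 h (a higher number here means a weaker inhibitor, a lower number a stronger inhibitor), compound 1 (`COc1cc(/C=C2\CN(S(=O)(=O)c3ccc(F)cc3)C/C(=C\c3ccccc3F)C2=O)cc(OC)c1OC`) gives 6340 nM and compound 2 (`COc1cc(/C=C2\CN(S(=O)(=O)c3ccc(F)cc3)C/C(=C\c3cccc([N+](=O)[O-])c3)C2=O)cc(OC)c1OC`) gives 4900 nM. Within the data shown here, these are the only two numbers so far, and a 1.3-fold lower number from compound 1 to compound 2 (0.11 log units; within the scatter) keeps compound 2 level with compound 1, so neither can be ranked above the other. The next change leads to compound 3 (`COc1cc(/C=C2\CN(S(=O)(=O)c3ccc(F)cc3)C/C(=C\c3ccc(C#N)cc3)C2=O)cc(OC)c1OC`): 4-cyanophenyl in place of 3-nitrophenyl on a double-bonded chain carbon bound to a double-bonded ring carbon. This puts 4-cyanophenyl in place of 3-nitrophenyl on a double-bonded chain carbon bound to a double-bonded ring carbon, while the rest of the structure stays unchanged.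

Among the measured compounds shown here, only one measured step bears on this change, since it concerns the same place: a 1.3-fold lower number from compound 1 to compound 2 (0.11 log units; within the scatter). That exchange of 2-fluorophenyl for 3-nitrophenyl did not move the number beyond the scatter in this assay. For the measured compounds named here, no compound measured so far carries 4-cyanophenyl, so this evidence is thin and the range is kept wide. No shift beyond the scatter is expected, in either direction. The expected step is a 1.0-fold higher number from compound 2 to compound 3 (0.01 log units; within the scatter). Compound 3 is estimated at 5000 nM, with an expected range of 2200 nM to 11000 nM.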

Compound 3, half-maximal inhibitory concentration: 4120 nM
Beside the measured number, compound 3's estimate is 1.2-fold (0.08 log units) above it, within the range that was stated.
By their numbers in this assay, from the lowest: compounds 3, 2 and 1 (each within the scatter of the next).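

Notes on the place on a double-bonded chain carbon bound to a double-bonded ring carbon: in this assay, the new entry gives a 1.2-fold lower number from compound 2 to compound 3 (0.08 log units; within the scatter) and a 1.5-fold lower number from compound 1 to compound 3 (0.19 log units; within the scatter), so both steps to compound 3 stay inside the scatter. Earlier, this place rested on a single exchange, whereas 2-fluorophenyl, 3-nitrophenyl and 4-cyanophenyl now form a set of three groups that the numbers cannot separate, even though the last exchange replaces 2 hydrogen-bond acceptors with 1 hydrogen-bond acceptor and a double bond outside the aromatic ring with a triple bond. No accompanying measurement bears on why the numbers stay together.

On these data alone, all three groups at this place are substituted phenyl rings, so it remains open whether a basic amine, a carboxylic acid or a longer alkyl chain there would produce a step beyond the scatter. Also open, as far as these compounds go, is whether the same flat response holds in any other cell line or at any other place on the shared core, since every comparison so far concerns this one place and this one read-out.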